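The source may report more compounds than this note shows. Statements on the series, on what has been measured and on what is new or still open speak of the compounds shown alone.

Compound 1 `C#CCn1cc(C(=O)NC(CC(=O)Nc2ccccn2)c2ccccc2)c(=O)c2ccc(Cl)nc21` gives 2900 nM in a functional assay on SW-620 cells (Homo sapiens) for cytotoxicity, read by MTT assay, with a stated time of 72 h; on this read-out higher numbers stand for weaker inhibition and lower numbers for stronger inhibition. Compound 2 `C#CCn1cc(C(=O)NC(CC(=O)NC2CCCC2)c2ccccc2)c(=O)c2ccc(Cl)nc21` differs from it by cyclopentyl in place of pyridin-2-yl on an amide-type nitrogen and gives 2700 nM, a step of a 1.1-fold lower number from compound 1 to compound 2 (0.03 log units; within the scatter). Compound 3 `C#CCn1cc(C(=O)NC(CC(=O)Nc2ccccn2)c2ccccc2)c(=O)c2cc(F)c(Cl)nc21` carries a different core, (fluoro in place of hydrogen on an aromatic carbon), and gives 2300 nM, a step of a 1.3-fold lower number from compound 1 to compound 3 (0.10 log units; within the scatter). Compound 4 `C#CCn1cc(C(=O)NC(CC(=O)NC2CCCC2)c2ccccc2)c(=O)c2cc(F)c(Cl)nc21` has not yet been measured in this assay; it stands to compound 3 exactly as compound 2 stands to compound 1, the same change, (cyclopentyl in place of pyridin-2-yl on an amide-type nitrogen), at the same place. This change has so far been made once, from compound 1 to compound 2, and stayed within the usual scatter there. A step of a 1.0-fold lower number from compound 3 to compound 4 (0.02 log units; within the scatter) is therefore expected from compound 3 to compound 4 in this assay, resting on the step of a 1.1-fold lower number from compound 1 to compound 2 (0.03 log units; within the scatter) seen with the other core. Compound 4 is expected to give about 2200 nM in this assay, with a range estimated from 1100 nM to 4400 nM.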

Compound 4, half-maximal inhibitory concentration: 2100 nM
Compound 4: the middle estimate sits 1.0-fold (0.02 log units) above what was measured, within the range that was stated.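

In this assay, cyclopentyl in place of pyridin-2-yl on the amide-type nitrogen gives a 1.1-fold lower number from compound 3 to compound 4 (0.04 log units; within the scatter), and the change carries from one core to the other: the same change on two cores in this assay, a 1.1-fold lower number (0.03 log units; within the scatter) from compound 1 to compound 2 and a 1.1-fold lower number (0.04 log units; within the scatter) from compound 3 to compound 4, 1.0-fold (0.01 log units) apart, within the scatter of two such steps. Fluoro in place of hydrogen on an aromatic carbon gives a 1.3-fold lower number from compound 2 to compound 4 (0.11 log units; within the scatter), and it carries over in the same way: the same change on two cores in this assay, a 1.3-fold lower number (0.10 log units; within the scatter) from compound 1 to compound 3 and a 1.3-fold lower number (0.11 log units; within the scatter) from compound 2 to compound 4, 1.0-fold (0.01 log units) apart, within the scatter of two such steps. Among these compounds, since every one of these steps lies within the scatter, the agreement shows only that neither change shifts the number measurably on these two cores, and it does not show how a change with a larger step would transfer.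

The compounds shown leave open whether a step beyond the scatter would appear with another group on the amide-type nitrogen, such as a longer alkyl chain or a chain ending in a carboxylic acid. They also leave open what an amine in place of the chloro group would do.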